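A few compounds are considered here, and "the series" means these few. Any claim that something is new, unique, unknown or untested is made for them only; others in the source may bear on it.

Compound 1 `C/C=C1/[C@H](O[C@@H]2O[C@H](CO)[C@@H](O)[C@H](O)[C@H]2O)OC=C(C(=O)OC)[C@H]1CC(=O)O`: > 15000 nM
Compound 2 `C/C=C1/[C@H](O[C@@H]2O[C@H](COC(C)=O)[C@@H](OC(C)=O)[C@H](OC(C)=O)[C@H]2OC(C)=O)OC=C(C(=O)OC)[C@H]1CC(=O)OCCCCCCCCCCCCCCC`: 3810 nM
Compound 3 `C#CCOC(=O)C[C@@H]1C(C(=O)OC)=CO[C@@H](O[C@@H]2O[C@H](COC(C)=O)[C@@H](OC(C)=O)[C@H](OC(C)=O)[C@H]2OC(C)=O)/C1=C/C`: > 15000 nM

All three compounds were tested in a functional assay on SK-BR-3 cells (Homo sapiens) for antiproliferative activity, read by MTT assay, with a stated time of 72 h; on this read-out lower numbers stand for stronger inhibition and higher numbers for weaker inhibition. For compound 1 the value > 15000 nM is a limit of the assay, not a number. Compound 3 likewise gives only a limit, > 15000 nM. Going by the values given here, compound 2 is the one compound with a number, 3810 nM. Compound 1 therefore stands at the limit of > 15000 nM in this assay, at which 2 of the 3 values shown sit.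

Compound 4 `C/C=C1/[C@H](O[C@@H]2O[C@H](CO)[C@@H](O)[C@H](O)[C@H]2O)OC=C(C(=O)OC)[C@H]1CC(=O)OCCC1CCCCC1` differs from compound 1 in one place: 2-cyclohexylethyl in place of hydrogen on an oxygen next to a carbonyl group. Among the compounds with values here, no two measured compounds differ in just one place, so the size of such a step has no measured precedent here. Compound 1 sits at the limit, so only a move toward stronger inhibition could be seen, and that move is expected to be small and uncertain, as the expected step from compound 1 to compound 4 is an at least 1.2-fold lower number from compound 1 to compound 4 (0.09 log units; that floor lies within the scatter). Compound 4 is expected near 12000 nM, within 4000 nM to 20000 nM.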

Compound 4, half-maximal inhibitory concentration: 2000 nM
Compound 4: middle estimate off by 6.0-fold (0.78 log units), on the high side; the measured number lies below the stated range.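

Going by these compounds alone, putting 2-cyclohexylethyl in place of hydrogen on an oxygen next to a carbonyl group is the first single change that can be read here, and in this assay it gives an at least 7.5-fold lower number from compound 1 to compound 4 (0.87 log units; beyond the scatter). This position therefore accepts the group, and the change moves the core of compound 1 from a limit to a real number. Compound 1 gives only a limit, so the full size of the step stays unknown: the limit of > 15000 nM in this assay, at which 2 of the 4 values shown sit.

As far as these compounds go, whether the ring itself matters remains open. The compounds shown do not compare 2-cyclohexylethyl with a straight octyl chain or a 2-phenylethyl group on the same oxygen.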